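A few compounds are considered here, and "the series" means these few. Any claim that something is new, unique, unknown or untested is made for them only; others in the source may bear on it.

Measured in an ADME assay on the whole organism (Rattus norvegicus, strain Wistar Han) for pharmacokinetics, read by LC-MS, with a stated time of 7 h, at a dose of 1 mg/kg by the intravenous route; a higher number here means faster removal of the compound, a lower number slower removal:
Compound 1 `CNC(=O)c1cc(C(=O)NC2CC2)cn([C@H](C)c2ccccc2)c1=O`: 72 mL/min/kg
Compound 2 `CNC(=O)c1cc(C(=O)NC2CC2)cn(Cc2cccc([C@@H](C)O)c2)c1=O`: 74 mL/min/kg

In this assay, compound 2 gives 74 mL/min/kg, which lies within the scatter of compound 1 at 72 mL/min/kg. Compound 3 `CNC(=O)c1cc(C(=O)NC2CC2)cn(Cc2cccc3c2CCN3)c1=O` carries 2,3-dihydro-1H-indol-4-yl in place of 3-(1-hydroxyethyl)phenyl on a saturated chain carbon bound to an aromatic nitrogen. For the measured compounds named here, no measured pair differs in one place, so the data give no direct guide to this change. No shift beyond the scatter is expected in this assay. The expected change is a 1.2-fold lower number from compound 2 to compound 3 (0.08 log units; within the scatter). Compound 3 is estimated at 62 mL/min/kg, with an expected range of 30 mL/min/kg to 105 mL/min/kg.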

Compound 3, clearance: 16 mL/min/kg
Estimate against measurement, compound 3: 3.9-fold (0.59 log units) above; the whole stated range lies above it.
By their numbers in this assay, from the lowest: compound 3; then compounds 1 and 2 (each within the scatter of the next).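

In this assay the group on a saturated chain carbon bound to an aromatic nitrogen can shift the number: 2,3-dihydro-1H-indol-4-yl in place of 3-(1-hydroxyethyl)phenyl gives a 4.6-fold lower number from compound 2 to compound 3 (0.67 log units; beyond the scatter). The two groups have the same heavy-atom count and the same hydrogen-bond donor and acceptor counts, yet the step lies beyond the scatter. No measurement at hand bears on the reason for this step. On these data alone, whether the lower number goes with the ring nitrogen or with the five-membered ring as a whole stays open. A five-membered ring of carbon only, or an acetyl group on that nitrogen, would bear on this.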